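The compounds below may be only part of what the source reports. "The series", "measured", "known", "first", "only" and "open" are said of these compounds alone.

Compound 1 `CCCCCCCCCCCCCCCCCCCC(N)=O` is a long saturated chain ending in a primary amide. In an assay on HEK293 cells for antagonist activity at transient receptor potential cation channel subfamily V member 2 (Rattus norvegicus), read by fluorescence and calcium flux, with a stated time of 5 min (on this read-out lower numbers stand for stronger inhibition and higher numbers for weaker inhibition), compound 1 gives > 10000 nM, which is a limit of the assay rather than a number. Compound 3 `CCCCCCC(=O)CC(O)CCCCCCCCC(=O)NCc1ccc(O)c(OC)c1` carries a ketone and a hydroxyl along its chain; in this assay compound 3 gives > 10000 nM, again a limit. Within the data shown here, compound 2 `CCCCCCCCCCCCCCCCCCCC(=O)NCc1ccc(O)c(OC)c1` carries a 4-hydroxy-3-methoxybenzyl group on the amide nitrogen and is the one compound with a number: in this assay compound 2 gives 3100 nM. Compound 1 therefore stands at the weak end of the set, at the limit of > 10000 nM in this assay, at which 2 of the 3 values shown sit.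

Among the measured compounds shown here, the only measured step is an at least 3.2-fold lower number from compound 1 to compound 2 (0.50 log units; beyond the scatter), a change at the amide nitrogen. The step to compound 4 `CCCCCCCCCCCCCCCC(N)=O` is of another kind: hydrogen in place of butyl on a saturated chain carbon, ten or more bonds along the chain from a carbonyl carbon. The chain is shortened while the nitrogen keeps both hydrogens. No measured step alters chain length alone, so nothing shown speaks for a move, and the one group shown to improve the number is absent from compound 4. The expected step is therefore a step that the limit leaves unreadable from compound 1 to compound 4, within the usual scatter. Compound 4 is estimated at 15000 nM, with a range from 7000 nM to 40000 nM, and is most likely to be reported once more as a limit.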

Compound 4, half-maximal inhibitory concentration: > 10000 nM
Compound 4 ended at the assay's limit (the forecaster's own chance of this, stated with the estimate: 85%); the middle value does not contradict the limit.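

In this assay compound 4 gives > 10000 nM, a limit of the assay and not a number. Compound 1 also sits at a limit, so the step between them cannot be read. The compounds shown leave open whether a shorter chain changes the number when the 4-hydroxy-3-methoxybenzyl group is on the amide nitrogen.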